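A few compounds are considered here, and "the series" means these few. Any claim that something is new, unique, unknown or untested is made for them only; others in the source may bear on it.

In a functional assay on HT-29 cells (Homo sapiens) for antiproliferative activity, read by sulforhodamine B assay, with a stated time of 48 h (on this read-out higher numbers stand for weaker inhibition and lower numbers for stronger inhibition), compound 1 `CCCN1CCN(c2ccc(S(=O)(=O)Oc3ccccc3CC)cc2)C1=O` gives > 100000 nM, which is a limit of the assay and not a number. Compound 2 `CCCN1CCN(c2ccc(S(=O)(=O)Oc3cccc(OC)c3)cc2)C1=O` gives 25000 nM, and compound 3 `CCCN1CCN(c2ccc(S(=O)(=O)Oc3cccc(F)c3)cc2)C1=O` gives 18000 nM. Those two numbers are close, with a 1.4-fold lower number from compound 2 to compound 3 (0.14 log units; within the scatter), so compound 3 stands level with compound 2. Both stand clear of compound 1, with an at least 4.0-fold lower number from compound 1 to compound 2 (0.60 log units; beyond the scatter) and an at least 5.5-fold lower number from compound 1 to compound 3 (0.74 log units; beyond the scatter).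

Compound 4 `CCCN1CCN(c2ccc(S(=O)(=O)Oc3ccc(OC)cc3)cc2)C1=O` differs from compound 3 at one place, with 4-methoxyphenyl in place of 3-fluorophenyl on an oxygen. For the measured compounds named here, compound 2 also carries a methoxy group, but not as the same 4-methoxyphenyl, so no measured step matches this change exactly. The nearest guide is the exchange of fluoro and methoxy, which stayed small in a 1.4-fold lower number from compound 2 to compound 3 (0.14 log units; within the scatter). The larger steps from compound 1 involve a different group and say less here. The expected change is therefore small, and a 1.2-fold higher number from compound 3 to compound 4 (0.09 log units; within the scatter) is estimated to stay within the scatter. The estimate for compound 4 is 22000 nM, with an expected range from 8000 nM to 70000 nM.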

Compound 4, half-maximal inhibitory concentration: 16000 nM
Compound 4: the middle estimate sits 1.4-fold (0.14 log units) above what was measured; measured number inside the range.
By their numbers in this assay, from the lowest: compounds 4, 3 and 2 (each within the scatter of the next). At a limit, above all of these: compound 1.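

With 4-methoxyphenyl on the oxygen bonded to the sulfonyl sulfur, the number in this assay cannot be told apart from that with 3-methoxyphenyl, with a 1.6-fold lower number from compound 2 to compound 4 (0.19 log units; within the scatter), or from that with 3-fluorophenyl, with a 1.1-fold lower number from compound 3 to compound 4 (0.05 log units; within the scatter). A third group at this place therefore joins the other two on the same side of the gap to 2-ethylphenyl, with an at least 6.2-fold lower number from compound 1 to compound 4 (0.79 log units; beyond the scatter). The reading for compound 1 is a limit and not a number, so the true size of that gap stays unknown: the limit of > 100000 nM in this assay, at which 1 of the 4 values shown sits.

The compounds shown leave open whether the gap belongs to the ethyl group itself or to where it sits, a question that a 4-ethylphenyl or 2-methoxyphenyl partner could address. They also leave open what an amine or a carboxylic acid in place of the methoxy group would do to the number.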